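Acetyl for methyl across two cores: lipophilicity measured

A few compounds are considered here, and "the series" means these few. Any claim that something is new, unique, unknown or untested is made for them only; others in the source may bear on it.

Measured compounds:
compound 1, `COCc1cc(N)c(Nc2ccc(C#N)cc2)cc1Oc1c(C)cc(/C=C/C#N)cc1C`, 4.13
compound 2, `CC(=O)OCc1cc(N)c(Nc2ccc(C#N)cc2)cc1Oc1c(C)cc(/C=C/C#N)cc1C`, 4.48
compound 3, `COCc1cc(N)c(Nc2ccc(C#N)cc2)cc1Oc1c(C)cc(CCC#N)cc1C`, 3.25

The study compares three measured compounds and one not yet measured, compound 4, `CC(=O)OCc1cc(N)c(Nc2ccc(C#N)cc2)cc1Oc1c(C)cc(CCC#N)cc1C`, in a physicochemical assay for lipophilicity, read by HPLC; a lower number here means a more polar compound, a higher number a more lipophilic compound. Compound 1 and compound 2 differ in one place: acetyl in place of methyl on an oxygen on a saturated carbon. That change gave a number 0.35 log units higher from compound 1 to compound 2 (beyond the scatter).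

Compound 3 stands on a different core. The difference between the core of compound 1 and that of compound 3 is 2-cyanoethyl in place of 2-cyanoethenyl on an aromatic carbon, and that change gave a number 0.88 log units lower from compound 1 to compound 3 (beyond the scatter), so compound 3 has the lowest number of the three measured compounds.

Compound 4 carries the same change on the core of compound 3: acetyl in place of methyl on an oxygen on a saturated carbon. The place is the same in both cases, so it is the same change. Compound 4 is therefore expected to lie above compound 3 by about the step seen before, a number 0.35 log units higher from compound 3 to compound 4 (beyond the scatter), resting on a number 0.35 log units higher from compound 1 to compound 2 (beyond the scatter). For compound 4 the estimate in this assay is 3.6, with a range from 3.3 to 3.9.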

Compound 4, partition coefficient: 2.84
The estimate for compound 4 lay 0.76 log units above the measured number, and the stated range ends above it.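

In this assay acetyl in place of methyl on an oxygen on a saturated carbon gave a number 0.41 log units lower from compound 3 to compound 4 (beyond the scatter) on the core of compound 3, against a number 0.35 log units higher from compound 1 to compound 2 (beyond the scatter) on the core of compound 1 and so, among these four compounds, the same change ran in opposite directions and its step did not carry from one core to the other. Read the other way, 2-cyanoethyl in place of 2-cyanoethenyl gave a number 1.64 log units lower from compound 2 to compound 4 (beyond the scatter) among the acetyl compounds, in the same direction as a number 0.88 log units lower from compound 1 to compound 3 (beyond the scatter) among the methyl compounds but larger. With one pair on each core, this does not show which step is typical of the series, and nothing available bears on why the two steps differ.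

The compounds shown leave open whether a longer acyl chain such as propanoyl, an amine or a carboxylic acid in the place of acetyl would follow the core of compound 1 or that of compound 3. They also leave open how a third group in place of 2-cyanoethyl, such as a longer cyanoalkyl chain, would behave.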